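Moving a fluorine on a urea-linked phenyl ring

The source may hold more compounds than are shown below. What is called first, only, known or untested is meant among the compounds shown, and "the series" means these compounds.

Of the compounds shown here, three built on a shared core have been tested in an ADME assay on cells (Astrocyte, Homo sapiens) for cytotoxicity, read by WST assay, with a stated time of 72 h; on this read-out lower numbers stand for stronger inhibition and higher numbers for weaker inhibition. Compound 1 `O=C(Nc1cccc(F)c1)Nc1cc2ncncc2cc1OCc1cccc(Cl)c1` is known here only as a limit of this assay: in this assay compound 1 gives > 10000 nM, so no number is fixed for it. Compound 2 `O=C(Nc1ccc(Cl)c(Cl)c1)Nc1cc2ncncc2cc1OCc1cccc(F)c1` gives 7400 nM in this assay. Compound 3 `O=C(Nc1cccc(Cl)c1)Nc1cc2ncncc2cc1OCc1ccccc1` gives 7400 nM in this assay, a value within the usual scatter of compound 2. Compound 1 stands at the limit of > 10000 nM in this assay, at which 1 of the 3 values shown sits.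

Compound 4 `O=C(Nc1ccccc1F)Nc1cc2ncncc2cc1OCc1cccc(Cl)c1` has not yet been measured in this assay. It differs from compound 1 in one place: 2-fluorophenyl in place of 3-fluorophenyl on an amide-type nitrogen. Going by the values given here, no pair of measured compounds in this set shares that change, so nothing here shows how it acts on the half-maximal inhibitory concentration. Because compound 1 gives > 10000 nM, the expected outcome for compound 4 is a similarly weak result, most likely again only a limit. For compound 4 the expected step is a step that the limit leaves unreadable from compound 1 to compound 4, none beyond the scatter. Compound 4 is estimated at 12000 nM, in a range from 5000 nM to 30000 nM.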

Compound 4, half-maximal inhibitory concentration: 8700 nM
Compound 4: the middle estimate sits 1.4-fold (0.14 log units) above what was measured; measured number inside the range.
By their numbers in this assay, from the lowest: compounds 2, 3 and 4 (each within the scatter of the next). At a limit, above all of these: compound 1.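

Going by these compounds alone, compound 1 and compound 4 are the only pair here that differ in one place, so they alone isolate the swap of 2-fluorophenyl for 3-fluorophenyl on an amide-type nitrogen. Compound 1 is known only as a limit of the assay, > 10000 nM. In this assay the swap gives an at least 1.1-fold lower number from compound 1 to compound 4 (0.06 log units; that floor lies within the scatter), so a real change may exist, but its full size cannot be read because the starting point is a limit: the limit of > 10000 nM in this assay, at which 1 of the 4 values shown sits.

The compounds shown leave open how the number would respond if a nitrile or a methoxy group took the place of the fluorine on this ring. They also leave open whether an amine or a longer chain on this nitrogen, in place of the fluorophenyl ring, would move the number beyond the scatter.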